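Carboxyl moved on the benzyl arm: expected efficacy

The compounds below may be only part of what the source reports. "The series", "measured", "known", "first", "only" and "open" are said of these compounds alone.

Working notes on the series. Compound 1 `Cc1cc(OCc2c(-c3c(Cl)cccc3Cl)noc2C(C)C)ncc1[N+](=O)[O-]` gives 101% in an assay on isolated protein for agonist activity at Bile acid receptor (Homo sapiens), read by FRET; a higher number here means a larger maximal response, a lower number a smaller maximal response. Compound 2 `CC(C)c1onc(-c2c(Cl)cccc2Cl)c1COc1ccc(N(C)Cc2cccc(C(=O)O)c2)c(C(F)(F)F)n1` gives 102% in this assay, and compound 3 `CN(Cc1cccc(C(=O)O)c1)c1ccc(OCc2c(-c3c(Cl)cccc3Cl)noc2C2CC2)nc1C(F)(F)F` gives 102% in this assay. Compound 3 thus stands level with compound 2, the two together the highest of the three numbers, while the number of compound 1 lies within the scatter of both, so the three compounds cannot be ordered. Going by the values given here, the one measured step between neighbours, no change at the digits printed from compound 2 to compound 3 (within the scatter), concerns the group on an aromatic carbon of the shared core and left the response unchanged.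

Compound 4 `CN(Cc1ccc(C(=O)O)cc1)c1ccc(OCc2c(-c3c(Cl)cccc3Cl)noc2C2CC2)nc1C(F)(F)F` differs from compound 3 by 4-carboxyphenyl in place of 3-carboxyphenyl on a saturated chain carbon bound to a nitrogen on an aromatic ring. Among the compounds with values here, no measured step touches the carboxyphenyl arm, so nothing bears directly on this change; what the series does show is that every compound measured so far, whatever its variation, reaches the same level as the reference. On that basis the step from compound 3 to compound 4 is expected to fall within the scatter, a number 2 percentage points lower from compound 3 to compound 4 (within the scatter). Compound 4 is therefore estimated at 100% in this assay, with a range from 85% to 110%.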

Compound 4, largest response reached (reported as efficacy), in percent of the reference or control that the assay uses: 109%
Beside the measured number, compound 4's estimate is 9 percentage points below it; measured number inside the range.
By their numbers in this assay, from the lowest: compounds 1, 2, 3 and 4 (each within the scatter of the next).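

The carboxyphenyl arm, untouched by the earlier step, now has a measured change of its own: 4-carboxyphenyl in place of 3-carboxyphenyl on a saturated chain carbon bound to a nitrogen on an aromatic ring gives a number 7 percentage points higher from compound 3 to compound 4 (within the scatter) in this assay. The two compounds have the same atoms, joined differently, and the series now shows that the response in this assay does not separate these two placings of the carboxyl on the arm, so compound 3 and compound 4 cannot be ordered. No measurement in hand speaks to the origin of this result.

Still open, on these data alone, is whether the arm keeps this level of response when the carboxylic acid gives way to a tetrazole or a primary amide, or when the carboxylic acid sits on a longer chain in place of its direct attachment to the phenyl ring. Also open, as far as these compounds go, is whether compound 3 and compound 4 would separate on a read-out other than largest response, such as the concentration needed to reach it, and whether 4-carboxyphenyl behaves the same with isopropyl in place of cyclopropyl on the shared core.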